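Swapping Iodo for Cyano: What Cytotoxicity to Expect

A few compounds are considered here, and "the series" means these few. Any claim that something is new, unique, unknown or untested is made for them only; others in the source may bear on it.

Compound 1, `C=C(C)CNC(=S)Nc1cccc(C(F)(F)F)c1`: in an ADME assay on BHK cells (Mesocricetus auratus) for cytotoxicity, read by MTT assay, with a stated time of 96 h (a lower number here means that less compound is tolerated, a higher number that more compound is tolerated), compound 1 gives > 100000 nM, which is a limit of the assay and not a number.
Compound 2, `FC(F)(F)c1cccc(NC(=S)Nc2ccc(I)cc2)c1`: in this assay compound 2 gives 9400 nM.
Compound 3, `FC(F)(F)c1cccc(NC(=S)NCc2ccco2)c1`: in this assay compound 3 gives 48000 nM.

Compound 2 stands lowest of the two numbers shown, meaning the cells tolerated it least; the nearest number is reached by a 5.1-fold higher number from compound 2 to compound 3 (0.71 log units; beyond the scatter). The remaining value, that of compound 1, is only a limit (the limit of > 100000 nM in this assay, at which 1 of the 3 values shown sits).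

Compound 4, `N#Cc1ccc(NC(=S)Nc2cccc(C(F)(F)F)c2)cc1`, differs from compound 2 by cyano in place of iodo on an aromatic carbon. Among the compounds with values here, no measured step touches this kind of change. The steps that exist replace the whole group on the nitrogen: an at least 10-fold lower number from compound 1 to compound 2 (1.02 log units; beyond the scatter) and a 5.1-fold higher number from compound 2 to compound 3 (0.71 log units; beyond the scatter). Both of those remodel a far larger part of the molecule than one substituent on the ring, and the ring itself stays in place in compound 4. The expectation for compound 4 is therefore a step of little size, estimated as a 1.5-fold higher number from compound 2 to compound 4 (0.17 log units; within the scatter), with no clear direction beyond the scatter. For compound 4 the estimated value in this assay is 14000 nM, expected to lie between 5000 nM and 50000 nM.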

Compound 4, half-maximal cytotoxic concentration: 9500 nM
Compound 4: the middle estimate sits 1.5-fold (0.17 log units) above what was measured, and the stated range covers the measured number.
By their numbers in this assay, from the lowest: compounds 2 and 4 (each within the scatter of the next); then compound 3. At a limit, above all of these: compound 1.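

In this assay, cyano in place of iodo on an aromatic carbon, para to a large group, gives a 1.0-fold higher number from compound 2 to compound 4 (0.00 log units; within the scatter), so the two compounds cannot be told apart. Within the data shown here, this is the first measured change on the ring itself: the earlier steps all altered the group on the nitrogen, whereas here only one ring substituent differs, with the iodine atom giving way to a carbon and a nitrogen joined by a triple bond, which adds a hydrogen-bond acceptor, and the number stays within the scatter. Among the compounds shown, every step beyond the scatter is therefore one that changes the group on the nitrogen, while this single swap on the ring is not.

From the compounds shown here alone, whether this holds for other groups at the same place on the ring, such as an amine, a carboxylic acid or a methoxy group, or for a nitrile elsewhere on that ring, stays open. The measurements shown offer no explanation for why compounds with iodo and cyano at this position give such similar numbers.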